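Benzyl for Cyclohexyl at the Ring Nitrogen of Compound 1

The compounds below may be only part of what the source reports. "The series", "measured", "known", "first", "only" and "open" are said of these compounds alone.

Compound 1 `O=Cc1ccc(-c2cn3ccnc3c(-c3ccc4ncn(C5CCCCC5)c4c3)n2)cc1` is the reference point of this small series. In a functional assay on SNB-19 cells (Homo sapiens) for inhibition, read by sulforhodamine B assay, with a stated time of 48 h, tested at 10 uM (a higher number here means more inhibition at the concentration tested (going by the name of the read-out), a lower number less inhibition), compound 1 gives 14.4%, the highest of the three numbers measured; compound 2 `CC(=O)c1ccc(-c2cn3ccnc3c(-c3ccc4ncn(C5CCCCC5)c4c3)n2)cc1` gives 3.96% and compound 3 `FC(F)(F)c1cccc(-c2cn3ccnc3c(-c3ccc4ncn(C5CCCCC5)c4c3)n2)c1` gives 2.24%. The two measured steps away from compound 1 both go downward beyond the scatter: a number 10.4 percentage points lower from compound 1 to compound 2 (beyond the scatter) with a methyl in place of hydrogen on a carbonyl carbon, and a number 12.2 percentage points lower from compound 1 to compound 3 (beyond the scatter) with 3-(trifluoromethyl)phenyl in place of 4-formylphenyl on an aromatic carbon. The step between compound 2 and compound 3, a number 1.7 percentage points lower from compound 2 to compound 3 (within the scatter), lies within the scatter.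

Compound 4 `O=Cc1ccc(-c2cn3ccnc3c(-c3ccc4ncn(Cc5ccccc5)c4c3)n2)cc1` differs from compound 1 at a different place: benzyl in place of cyclohexyl on an aromatic nitrogen. Among the measured compounds shown here, none of the measured steps touches this aromatic nitrogen; all three concern the aryl group on the other side of the shared core. For the measured compounds named here, there is therefore no directly relevant step, and the only thing known is that changes on the aryl side cost inhibition. With no guidance at the ring nitrogen, the expected step is a number 2.4 percentage points lower from compound 1 to compound 4 (within the scatter), essentially no change beyond the scatter. Compound 4 is accordingly estimated to show 12% in this assay, within a range from 0% to 28%.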

Compound 4, a percentage reported as inhibition, at one concentration (the size of the read-out at that concentration, not a potency): 14.4%
Beside the measured number, compound 4's estimate is 2.4 percentage points below it; measured number inside the range.
By their numbers in this assay, from the lowest: compounds 3 and 2 (each within the scatter of the next); then compounds 1 and 4 (each within the scatter of the next).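

In this assay benzyl in place of cyclohexyl on an aromatic nitrogen gives no change at the digits printed from compound 1 to compound 4 (within the scatter) as the first step seen at this position. Unlike the aryl side of compound 1, where both measured steps went downward beyond the scatter, this ring nitrogen takes a six-membered aromatic ring of carbon on a benzyl group in place of a six-membered non-aromatic ring of carbon with no shift in the read-out. This rests on one pair at a single concentration, with the 4-formylphenyl group held in place, so it shows that the two groups are not told apart here and says nothing about potency. Nothing available here explains why the two groups read alike.

On these data alone, it remains open whether the same nitrogen would accept groups of another kind, such as an amine on a longer chain, a carboxylic acid or a plain methyl. As far as these compounds go, it is also open whether benzyl would read the same alongside the 4-acetylphenyl group of compound 2 or the 3-(trifluoromethyl)phenyl group of compound 3.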